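Swapping 3-nitrophenyl for 4-chlorophenyl

A few compounds are considered here, and "the series" means these few. Any claim that something is new, unique, unknown or untested is made for them only; others in the source may bear on it.

Compound 1 `COc1cc(C(=O)c2cn(-c3cccc(Br)c3)cc2-c2ccccc2)cc(OC)c1OC` gives 78 nM
Compound 2 `COc1cc(C(=O)c2cn(-c3cccc([N+](=O)[O-])c3)cc2-c2ccccc2)cc(OC)c1OC` gives 550 nM

In a functional assay on MCF7 cells (Homo sapiens) for cytotoxicity, read by MTT assay, with a stated time of 96 h (a higher number here means a weaker inhibitor, a lower number a stronger inhibitor), compound 2 has the higher of the two numbers. Compound 3 `COc1cc(C(=O)c2cn(-c3ccc(Cl)cc3)cc2-c2ccccc2)cc(OC)c1OC` differs from it on an aromatic nitrogen, with 4-chlorophenyl in place of 3-nitrophenyl (4-chlorophenyl in place of 3-nitrophenyl on an aromatic nitrogen). Among the measured compounds shown here, only one measured step bears on this: a 7.1-fold higher number from compound 1 to compound 2 (0.85 log units; beyond the scatter), nitro in place of bromo. Compound 3 also lacks the nitro group, though its 4-chlorophenyl is not the group of compound 1, so a smaller step toward a lower number is expected. The expected change is a 3.7-fold lower number from compound 2 to compound 3 (0.56 log units; beyond the scatter). Compound 3 is estimated at 150 nM, with an expected range of 40 nM to 500 nM.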

Compound 3, half-maximal inhibitory concentration: 140 nM
Compound 3: middle estimate off by 1.1-fold (0.03 log units), on the high side; the range from low to high includes it.
By their numbers in this assay, from the lowest: compounds 1 and 3 (each within the scatter of the next); then compound 2.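

In this assay, the aromatic nitrogen accepts a change of both the substituent and its place on the phenyl group: 4-chlorophenyl in place of 3-nitrophenyl gives a 3.9-fold lower number from compound 2 to compound 3 (0.59 log units; beyond the scatter) and so recovers most of what the nitro step lost. The two halogen-bearing compounds remain close, with a 1.8-fold higher number from compound 1 to compound 3 (0.25 log units; within the scatter) within the scatter, leaving compound 2 apart from both. Nothing available explains this difference.

Since compound 1 and compound 3 differ in both halogen and placement, these effects remain unseparated, and 3-chlorophenyl would be needed to divide them. On these data alone, how an amine or a carboxylic acid on this phenyl group would read also remains open.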